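From Ethoxy to Propoxy on the Shared Core

The source may hold more compounds than are shown below. What is called first, only, known or untested is meant among the compounds shown, and "the series" means these compounds.

In a functional assay on MCF7 cells (Homo sapiens) for antiproliferative activity, read by sulforhodamine B assay, with a stated time of 3 days (a higher number here means that more compound is needed for the effect, a lower number that less compound is needed), compound 3 (`CCCC1=C(OCC)C(CCC)(CCC)C(=O)/C(=C(O)\C=C\c2ccccc2)C1=O`) gives 2.6 uM and sits within the scatter of compound 2 (`CCCC1=C(OCC(C)C)C(CCC)(CCC)C(=O)/C(=C(O)\C=C\c2ccccc2)C1=O`), which gives 4.4 uM in the same test, while compound 1 (`CCCC1=C(OCCC(C)C)C(CCC)(CCC)C(=O)/C(=C(O)\C=C\c2ccccc2)C1=O`) gives 9.1 uM and stands clearly higher. Compound 4 (`CCCOC1=C(CCC)C(=O)/C(=C(O)/C=C/c2ccccc2)C(=O)C1(CCC)CCC`) turns ethoxy into propoxy (methyl in place of hydrogen on a saturated chain carbon, two bonds along the chain from an oxygen on an unsaturated carbon), with methyl in place of hydrogen on a saturated chain carbon, two bonds along the chain from an oxygen on an unsaturated carbon. The closest guide is a 3.5-fold lower number from compound 1 to compound 3 (0.54 log units; beyond the scatter) for the same place, where hydrogen replaced the larger isopropyl. Nearby, a 1.7-fold lower number from compound 2 to compound 3 (0.23 log units; within the scatter) and a 2.1-fold lower number from compound 1 to compound 2 (0.32 log units; beyond the scatter) are also small. The expected change is a slight rise within the scatter, an estimated 1.3-fold higher number from compound 3 to compound 4 (0.10 log units; within the scatter) in this assay for this smaller addition. For compound 4 the estimated value is 3.3 uM with an expected range from 1.8 uM to 5.6 uM in that test.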

Compound 4, concentration for half-maximal effect: 1.6 uM
Estimate against measurement, compound 4: 2.1-fold (0.31 log units) above; measured number outside the range, below it.
By their numbers in this assay, from the lowest: compounds 4, 3 and 2 (each within the scatter of the next, the first and the last beyond it); then compound 1.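

Going from ethoxy to propoxy stays within the scatter, a 1.6-fold lower number from compound 3 to compound 4 (0.21 log units; within the scatter), so this position accepts the added methyl with no clear change. Compound 4 does stand apart from the compounds with the larger groups, a 2.8-fold lower number from compound 2 to compound 4 (0.44 log units; beyond the scatter) and a 5.7-fold lower number from compound 1 to compound 4 (0.75 log units; beyond the scatter). Replacing isopropyl with methyl also does not give one fixed step size, since its effect depends on the compound in which it is made:
the same change on two cores in this assay, a 1.7-fold lower number (0.23 log units; within the scatter) from compound 2 to compound 3 and a 5.7-fold lower number (0.75 log units; beyond the scatter) from compound 1 to compound 4, 3.4-fold (0.53 log units) apart, beyond the scatter of two such steps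

Going by these compounds, what remains open is how a butoxy chain, or a propoxy chain ending in an amine, would read at this position.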